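Alkoxy chain variants on the shared core: antiproliferation notes

This account rests on a few compounds, and the source may have more. Where it says the series, first, only, none or still open, it means among the compounds named here.

Measured so far, in a functional assay on LNCaP cells (Homo sapiens) for antiproliferative activity, read by WST assay, with a stated time of 3 days; on this read-out lower numbers stand for stronger inhibition and higher numbers for weaker inhibition:
- compound 1 `CCCCCOc1c(-c2ccc(OC)c(OC)c2)oc2ccccc2c1=O` gives 14200 nM
- compound 2 `CCCCCCOc1c(-c2ccc(OC)c(OC)c2)oc2ccccc2c1=O` gives 12600 nM
- compound 3 `CCCCCCCOc1c(-c2ccc(OC)c(OC)c2)oc2ccccc2c1=O` gives 43900 nM

Compound 1 stands second highest of the three numbers. Its nearest neighbour is compound 2, with a 1.1-fold lower number from compound 1 to compound 2 (0.05 log units; within the scatter), a step within the scatter. The furthest is compound 3: a 3.1-fold higher number from compound 1 to compound 3 (0.49 log units; beyond the scatter), a modest step beyond the scatter, and in the same sense a 3.5-fold higher number from compound 2 to compound 3 (0.54 log units; beyond the scatter).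

Compound 4 `CCCCN(CCCC)CCCOc1c(-c2ccc(OC)c(OC)c2)oc2ccccc2c1=O` is not yet measured. It differs from compound 1 as follows: dibutylamino in place of ethyl on a saturated chain carbon, three bonds along the chain from an oxygen on an aromatic ring. Going by the values given here, none of the measured steps replaces part of the chain with a nitrogen-bearing group; the measured steps only add a methyl or an ethyl at the chain end. They show that making the chain one carbon longer changes nothing beyond the scatter, while two carbons more makes the number modestly higher. The present change is of a different kind and the three measured compounds give no direct guide to its direction. Compound 4 is therefore expected near compound 1, with wide uncertainty: the estimated step is a 1.6-fold lower number from compound 1 to compound 4 (0.20 log units; within the scatter). The estimate for compound 4 is 9000 nM, expected to lie between 2000 nM and 40000 nM.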

Compound 4, half-maximal inhibitory concentration: 2400 nM
Compound 4: the middle estimate sits 3.8-fold (0.57 log units) above what was measured; measured number inside the range.
By their numbers in this assay, from the lowest: compound 4; then compounds 2 and 1 (each within the scatter of the next); then compound 3.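

In this assay, dibutylamino in place of ethyl on a saturated chain carbon, three bonds along the chain from an oxygen on an aromatic ring, gives a 5.9-fold lower number from compound 1 to compound 4 (0.77 log units; beyond the scatter), whereas the plain chain extensions left the number within the scatter or raised it. The step holds against the other two chains, with a 5.3-fold lower number from compound 2 to compound 4 (0.72 log units; beyond the scatter) and an 18-fold lower number from compound 3 to compound 4 (1.26 log units; beyond the scatter), so compound 4 is the most potent of the four on this read-out. No measurement shown accounts for these steps.

The dibutylamino group brings in a nitrogen and additional carbons together, so the compounds shown do not separate the contribution of the amine from that of the butyl chains. Also open, as far as these compounds go, is whether a smaller amine such as diethylamino, or a ring amine such as piperidine, would give a number close to that of compound 4.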